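Halogen Swap on the Aryl Group and Expected Tolerance

The source may hold more compounds than are shown below. What is called first, only, known or untested is meant among the compounds shown, and "the series" means these compounds.

Compound 2 `O=c1[nH]cc(S(=O)(=O)Nc2cccc(-c3cn(-c4ccccc4F)nn3)c2)c(=O)[nH]1` carries a 2-fluorophenyl group on an aromatic nitrogen of the shared core. In an ADME assay on L02 cells (Homo sapiens) for cytotoxicity, read by MTT assay, with a stated time of 24 h (a lower number here means that less compound is tolerated, a higher number that more compound is tolerated), compound 2 is reported as "not toxic" (no number reported), so no single number stands for it. The only other result shown belongs to compound 1 `Cc1ccc(-n2cc(-c3ccccc3NS(=O)(=O)c3c[nH]c(=O)[nH]c3=O)nn2)cc1`, and in this assay compound 1 reaches > 100000 nM, which is a limit of the measurement and not a number. Both results point the same way, toward (the limit of > 100000 nM in this assay, at which 1 of the 2 values shown sits). Compound 3 `O=c1[nH]cc(S(=O)(=O)Nc2cccc(-c3cn(-c4ccc(Cl)cc4)nn3)c2)c(=O)[nH]1` differs from compound 2 by 4-chlorophenyl in place of 2-fluorophenyl on an aromatic nitrogen. Going by the values given here, no measured pair shows what such a swap does in this assay, so the expected step from compound 2 to compound 3 is none beyond the usual scatter, in neither direction. On that basis compound 3 is estimated at 100000 nM in this assay, with a range from 40000 nM to 300000 nM, and most likely reported again only as a limit.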

Compound 3, half-maximal cytotoxic concentration: 9860 nM
Compound 3: middle estimate off by 10-fold (1.01 log units), on the high side; the measured number lies below the stated range.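

Going by these compounds alone, compound 2 is reported only as "not toxic", without a number, so no step from compound 2 to compound 3 can be read. The compounds shown leave open whether the change from 2-fluorophenyl to 4-chlorophenyl alone shifts the result in this assay.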